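Cytotoxicity notes on the amine-substituted series

The compounds below may be only part of what the source reports. "The series", "measured", "known", "first", "only" and "open" are said of these compounds alone.

compound 1 `Cc1cn([C@@H]2O[C@H](CO[Si](C)(C)C(C)(C)C)[C@@]3(OS(=O)(=O)C=C3NCCC(=O)O)[C@H]2O[Si](C)(C)C(C)(C)C)c(=O)n(C)c1=O`: 11500 nM
compound 2 `COC(=O)CCNC1=CS(=O)(=O)O[C@@]12[C@@H](CO[Si](C)(C)C(C)(C)C)O[C@@H](n1cc(C)c(=O)n(C)c1=O)[C@@H]2O[Si](C)(C)C(C)(C)C`: > 250000 nM
compound 3 `Cc1cn([C@@H]2O[C@H](CO[Si](C)(C)C(C)(C)C)[C@@]3(OS(=O)(=O)C=C3NCC(=O)C(=O)N3CCC3)[C@H]2O[Si](C)(C)C(C)(C)C)c(=O)n(C)c1=O`: 17400 nM

In a functional assay on MT4 cells (Homo sapiens) (on this read-out lower numbers stand for higher toxicity in this test and higher numbers for lower toxicity in this test), compound 3 gives the highest of the two numbers; its nearest neighbour is compound 1, and the step of a 1.5-fold higher number from compound 1 to compound 3 (0.18 log units; within the scatter) lies within the scatter. The value of compound 2 is a limit of this assay, not a number. Compound 4 `COC(=O)NC1=CS(=O)(=O)O[C@@]12[C@@H](CO[Si](C)(C)C(C)(C)C)O[C@@H](n1cc(C)c(=O)n(C)c1=O)[C@@H]2O[Si](C)(C)C(C)(C)C` differs from compound 3 by methoxycarbonyl in place of (((azetidin-1-yl)carbonyl)carbonyl)methyl on an amine nitrogen. Both steps that bear on it run through compound 2 and its limit of > 250000 nM in this assay, at which 1 of the 3 values shown sits: an at least 21-fold higher number from compound 1 to compound 2 (1.33 log units; beyond the scatter) and an at least 14-fold lower number from compound 2 to compound 3 (1.15 log units; beyond the scatter). Compound 4 shares with compound 2 a methyl on an oxygen next to a carbonyl group, so a higher number is expected, of uncertain size. For compound 4 the expected value in this assay is 45000 nM, within 12000 nM to 250000 nM, an expected step of a 2.6-fold higher number from compound 3 to compound 4 (0.41 log units; beyond the scatter).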

Compound 4, half-maximal cytotoxic concentration: 29900 nM
The estimate for compound 4 lay 1.5-fold (0.18 log units) above the measured number, within the range that was stated.
By their numbers in this assay, from the lowest: compounds 1, 3 and 4 (each within the scatter of the next, the first and the last beyond it). At a limit, above all of these: compound 2.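

In this assay, methoxycarbonyl on the amine nitrogen reads level with (((azetidin-1-yl)carbonyl)carbonyl)methyl, with a 1.7-fold higher number from compound 3 to compound 4 (0.24 log units; within the scatter), yet it is set apart from 2-carboxyethyl by a 2.6-fold higher number from compound 1 to compound 4 (0.41 log units; beyond the scatter). Against 2-(methoxycarbonyl)ethyl the step is an at least 8.3-fold lower number from compound 2 to compound 4 (0.92 log units; beyond the scatter), so a methoxycarbonyl group alone does not bring a compound to the level of compound 2. The value of compound 2 is a limit, not a number: the limit of > 250000 nM in this assay, at which 1 of the 4 values shown sits.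

Open, from the compounds shown here alone, is how a (methoxycarbonyl)methyl on the amine nitrogen would read, lying in chain length between compound 4 and compound 2. Also open, going by these compounds, is whether a simple amide in place of the methoxycarbonyl would keep the reading of compound 4.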